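The compounds below may be only part of what the source reports. "The series", "measured", "known", "first", "only" and "open" are said of these compounds alone.

Working notes on the benzopyranone sulfonamide series.

Of the compounds shown here, three have been measured in a functional assay on MCF7 cells (Homo sapiens) for cytotoxicity, read by sulforhodamine B assay, with a stated time of 72 h; a higher number here means a weaker inhibitor, a lower number a stronger inhibitor. Compound 1 `Cc1cc(C)nc(NS(=O)(=O)c2ccc(NCc3coc4ccccc4c3=O)cc2)n1` gives 93600 nM. Compound 2 `O=C1/C(=C/c2coc3ccccc3c2=O)N=C(c2ccccc2)N1c1ccc(S(=O)(=O)Nc2ncccn2)cc1` returns only a limit of the assay, > 100000 nM, so no number stands for it. Compound 3 `CCOC1Oc2ccccc2C(=O)/C1=C/Nc1ccc(S(=O)(=O)Nc2cc(C)on2)cc1` gives 25800 nM, the lowest of the two numbers shown; its nearest neighbour on the scale is compound 1, whose number is higher by a gap beyond the scatter. Going by the values given here, the cores of compound 1, compound 2 and compound 3 differ from one another, so no single-point step is available among the measured compounds.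

Compound 4 `CCOC1Oc2ccccc2C(=O)/C1=C/Nc1ccc(S(=O)(=O)Nc2ncccn2)cc1` is yet to be measured. It differs from compound 3 at one place: pyrimidin-2-yl in place of 5-methyl-1,2-oxazol-3-yl on a sulfonamide nitrogen. Both groups are small aromatic rings carrying two hetero atoms and no hydrogen-bond donor, exchanged on the sulfonamide nitrogen next to the sulfonyl sulfur. Among the compounds with values here, with no measured pair isolating this exchange, the step in this assay is expected to be small, within or close to the scatter, with a lean toward a weaker inhibitor.

For compound 4 the estimate in this assay is 40000 nM, with a range of 12000 nM to 130000 nM. The step this expectation implies is a 1.6-fold higher number from compound 3 to compound 4 (0.19 log units; within the scatter).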

Compound 4, half-maximal inhibitory concentration: 30100 nM
Compound 4: middle estimate off by 1.3-fold (0.12 log units), on the high side; low and high end bracket the measured number.
By their numbers in this assay, from the lowest: compounds 3 and 4 (each within the scatter of the next); then compound 1. At a limit, above all of these: compound 2.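

In this assay, going by these compounds alone, compounds 3 and 4 form the first pair that differs in one place, and the exchange gives a 1.2-fold higher number from compound 3 to compound 4 (0.07 log units; within the scatter). On the core they share, this sulfonamide nitrogen therefore carries either a five-membered or a six-membered aromatic ring with 2 hetero atoms, with no difference beyond the scatter; compound 1 and compound 2, whose cores differ, could not show this. Nothing measured in this set bears on a cause for this step.

From the compounds shown here alone, both groups compared here are aromatic rings with 2 hetero atoms, so it remains open how this assay would respond on the same nitrogen to a plain hydrogen, a methyl group, a longer alkyl chain, or a chain ending in an amine or a carboxylic acid. Going by these compounds, it is also open whether the exchange of 5-methyl-1,2-oxazol-3-yl for pyrimidin-2-yl would give a similarly small step on the core of compound 1 or the core of compound 2.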